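Adding a trifluoromethyl group to the fluoroaryl sulfonamide series

The source may report more compounds than this note shows. Statements on the series, on what has been measured and on what is new or still open speak of the compounds shown alone.

Measured in a physicochemical assay for lipophilicity, at pH 7.4; a lower number here means a more polar compound, a higher number a more lipophilic compound:
- compound 1 `CCS(=O)(=O)c1ccc(CN(CC(C)C)S(=O)(=O)c2ccc3c(c2)C(O)CC(C2CCOCC2)O3)nc1`: 1.42
- compound 2 `CC(C)CN(c1ccc(F)cc1)S(=O)(=O)c1ccc2c(c1)C(O)CC(C1CCOCC1)O2`: 3.39
- compound 3 `CC(C)CN(c1cccc(F)c1)S(=O)(=O)c1ccc2c(c1)C(O)CC(C1CCOCC1)O2`: 3.39

In this assay compound 3 gives 3.39, level with compound 2 and well clear of compound 1. The next structure, compound 4 `CC(C)CN(c1ccccc1C(F)(F)F)S(=O)(=O)c1ccc2c(c1)C(O)CC(C1CCOCC1)O2`, carries 2-(trifluoromethyl)phenyl in place of 3-fluorophenyl on a sulfonamide nitrogen.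

Among the compounds with values here, two measured steps bear on this. Placing 3-fluorophenyl in place of 4-fluorophenyl gave no change at the digits printed from compound 2 to compound 3 (within the scatter). Placing 3-fluorophenyl in place of (5-(ethylsulfonyl)pyridin-2-yl)methyl gave a number 1.97 log units higher from compound 1 to compound 3 (beyond the scatter), but that step exchanges a very different group and is a poor guide to size. Within the data shown here, no measured step exchanges a fluorophenyl for a trifluoromethyl-bearing phenyl, so the expectation rests largely on the larger entering group. A modest rise is therefore expected, and the estimated step is a number 0.41 log units higher from compound 3 to compound 4 (beyond the scatter). For compound 4 the estimated value is 3.8, with an expected range from 3.4 to 4.2.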

Compound 4, distribution coefficient: 4.14
For compound 4 the middle estimate is 0.34 log units below the measured one, within the range that was stated.
By their numbers in this assay, from the lowest: compound 1; then compounds 2 and 3 (each within the scatter of the next); then compound 4.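

Putting 2-(trifluoromethyl)phenyl in place of either fluorophenyl on the sulfonamide nitrogen gave a number 0.75 log units higher from compound 3 to compound 4 (beyond the scatter) and a number 0.75 log units higher from compound 2 to compound 4 (beyond the scatter) in this assay and so shows that this position, unmoved by 3-fluorophenyl in place of 4-fluorophenyl, does answer to a change on the phenyl ring. The exchange with (5-(ethylsulfonyl)pyridin-2-yl)methyl now spans a number 2.72 log units higher from compound 1 to compound 4 (beyond the scatter) and is the widest step in the set. Nothing measured here accounts for the rise.

The step changes both the substituent and where it sits on the phenyl ring, and the compounds shown do not tell these two apart. Nor do they show how this position would respond to an unsubstituted phenyl, or to a phenyl bearing a nitrile or an amine.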